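The source may hold more compounds than are shown below. What is called first, only, known or untested is meant among the compounds shown, and "the series" means these compounds.

Compound 1 `CCCCCCCCCCCCCCn1cc(COC[C@@H]2OC[C@H](N)[C@@H]2O)nn1`: 8210 nM
Compound 2 `CCCCCCCCCCCCCCCCn1cc(COC[C@@H]2OC[C@H](N)[C@@H]2O)nn1`: 27900 nM
Compound 3 `CCCCCCCCCCCCCCCCCCn1cc(COC[C@@H]2OC[C@H](N)[C@@H]2O)nn1`: 15400 nM

In a functional assay on MGC-803 cells (Homo sapiens) for antiproliferative activity, read by MTT assay, with a stated time of 48 h (on this read-out higher numbers stand for weaker inhibition and lower numbers for stronger inhibition), compound 3 stands second highest of these three numbers. Its neighbours are close on both sides: the step of a 1.8-fold lower number from compound 2 to compound 3 (0.26 log units; within the scatter) and the step of a 1.9-fold higher number from compound 1 to compound 3 (0.27 log units; within the scatter) both lie within the scatter, so the three compounds cannot be ranked. Compound 4 `CCCCCCCCCCCCCCCCCCn1cc(COC[C@@H]2OC[C@H](N)[C@H]2O)nn1` keeps every atom and bond of compound 3; (the two compounds have the same atoms and bonds and differ only in configuration as drawn: 1 of 3 stereo elements differ; a stereocentre at a saturated ring carbon is drawn S in compound 3 and R in compound 4). Going by the values given here, none of the measured steps bears on such a change: each of them, including a 3.4-fold higher number from compound 1 to compound 2 (0.53 log units; beyond the scatter), alters only the length of the chain, and no pair in the set differs in configuration. With nothing to guide the direction, the expected step of no change at the digits printed from compound 3 to compound 4 (within the scatter) is none beyond the scatter, with wide uncertainty. Compound 4 is therefore estimated at 15400 nM, in the range 4000 nM to 60000 nM.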

Compound 4, half-maximal inhibitory concentration: 3110 nM
Estimate against measurement, compound 4: 5.0-fold (0.69 log units) above, outside the stated range (below it).
By their numbers in this assay, from the lowest: compound 4; then compounds 1, 3 and 2 (each within the scatter of the next, the first and the last beyond it).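

Until now only the chain length had varied. With the chain held fixed, inverting one saturated ring carbon from S to R gives a 5.0-fold lower number from compound 3 to compound 4 (0.69 log units; beyond the scatter) in this assay, so configuration at this position also moves the number. This shift, beyond the scatter, can be assigned to that stereocentre alone: the fact that compounds 3 and 4 differ only in the configuration as drawn

On these data alone, whether R at this carbon gives a similar change on the shorter chains of compound 1 and compound 2 remains open. Also open, as far as these compounds go, is how a carboxylic acid in place of the amine would behave.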